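From 4-methylbenzyl to propyl on the shared core

The source may hold more compounds than are shown below. What is called first, only, known or untested is meant among the compounds shown, and "the series" means these compounds.

In a functional assay on BGC-823 cells (Homo sapiens) for inhibition, read by MTT assay, with a stated time of 72 h (on this read-out lower numbers stand for stronger inhibition and higher numbers for weaker inhibition), three compounds with a shared core have been measured. Compound 1, `Cc1cc(N2CC[C@@H](C)[C@@H](N(C)c3ncnc4[nH]ccc34)C2)n2nc(SCc3nc4ccccc4[nH]3)nc2n1`, reads > 100000 nM, which is a limit and not a number. Compound 2, `Cc1cc(N2CC[C@@H](C)[C@@H](N(C)c3ncnc4[nH]ccc34)C2)n2nc(SCc3csc4ccc(Cl)cc34)nc2n1`, reads > 100000 nM, again a limit. Going by the values given here, compound 3, `Cc1ccc(CSc2nc3nc(C)cc(N4CC[C@@H](C)[C@@H](N(C)c5ncnc6[nH]ccc56)C4)n3n2)cc1`, gives 69500 nM, the only actual number in the set.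

Compound 4, `CCCSc1nc2nc(C)cc(N3CC[C@@H](C)[C@@H](N(C)c4ncnc5[nH]ccc45)C3)n2n1`, differs from compound 3 by one change: ethyl in place of 4-methylphenyl on a saturated chain carbon bound to a sulfur. The same difference can also be read as 4-methylbenzyl to propyl.

Among the compounds with values here, two measured steps bear on this position: an at least 1.4-fold lower number from compound 1 to compound 3 (0.15 log units; that floor lies within the scatter) and an at least 1.4-fold lower number from compound 2 to compound 3 (0.15 log units; that floor lies within the scatter). Each gives only a floor. The third, a step that the two limits leave unreadable from compound 1 to compound 2, gives no size at all. None of the three steps brings in a plain alkyl chain, so no step beyond the scatter is expected in this assay, in either direction. The expected step is a 1.0-fold higher number from compound 3 to compound 4 (0.00 log units; within the scatter). Compound 4 is estimated at 70000 nM, with an expected range from 30000 nM to 160000 nM.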

Compound 4, half-maximal inhibitory concentration: 51200 nM
Compound 4: the middle estimate sits 1.4-fold (0.14 log units) above what was measured; measured number inside the range.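

With ethyl in place of 4-methylphenyl on a saturated chain carbon bound to a sulfur, this assay shows a 1.4-fold lower number from compound 3 to compound 4 (0.13 log units; within the scatter) and so a plain propyl chain, with no ring, gives a number within the scatter of that from the 4-methylbenzyl group. The steps of an at least 1.9-fold lower number from compound 2 to compound 4 (0.29 log units; that floor lies within the scatter) and an at least 1.9-fold lower number from compound 1 to compound 4 (0.29 log units; that floor lies within the scatter) give floors only, and neither floor goes beyond the scatter. Compound 1 and compound 2 still read as limits and not numbers: the limit of > 100000 nM in this assay, at which 2 of the 4 values shown sit.

From the compounds shown here alone, the step from compound 1 to compound 2 cannot be read, and the true size of the steps from those two compounds to compound 4 stays open. Going by these compounds, what an amine, a carboxylic acid or a longer chain at this place would give in this assay also stays open, as does whether any group here yields a step beyond the scatter.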